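The compounds below may be only part of what the source reports. "The series", "measured", "known", "first", "only" and "open" are said of these compounds alone.

Measured in a functional assay on CPT30 cells for inhibition, with CPT30 cell line (Homo sapiens) as the target, read by MTT assay; on this read-out lower numbers stand for stronger inhibition and higher numbers for weaker inhibition:
- compound 1 `COc1ccc(C(=O)c2cc(OC)c(OC)c(OC)c2)c(N)c1`: 37.3 nM
- compound 2 `COc1cc(C(=O)c2cc(Cl)ccc2N)cc(OC)c1OC`: 60.3 nM

Compound 2, at 60.3 nM, lies within the scatter of compound 1, at 37.3 nM, so the two numbers do not separate these compounds. Compound 2 therefore stands level with the only other measured point in the series.

The next compound, compound 3 `COc1cc(C(=O)c2cc(Cl)ccc2O)cc(OC)c1OC`, has not yet been measured. It carries hydroxy in place of amino on an aromatic carbon, ortho to a large group and para to a chloro group: hydroxy in place of amino on an aromatic carbon. Among the compounds with values here, compound 1 and compound 2 both carry amino, and no measured compound carries hydroxy. Within the data shown here, no measured pair therefore shows the size of this change, and the expectation remains loose.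

A step beyond the scatter is expected in this assay, toward a higher number and so toward weaker inhibition. The expected move is a 5.8-fold higher number from compound 2 to compound 3 (0.76 log units; beyond the scatter). Compound 3 is estimated at 350 nM, with an expected range of 70 nM to 2500 nM.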

Compound 3, half-maximal inhibitory concentration: 5000 nM
The estimate for compound 3 lay 14-fold (1.15 log units) below the measured number, and the stated range ends below it.
By their numbers in this assay, from the lowest: compounds 1 and 2 (each within the scatter of the next); then compound 3.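

In this assay hydroxy in place of amino on this aromatic carbon, ortho to a large group and para to a chloro group, gives an 83-fold higher number from compound 2 to compound 3 (1.92 log units; beyond the scatter) and so marks a large step beyond the scatter. Compound 1 and compound 2 both carry amino and gave no size for any change at this carbon; this pair now shows that the number depends strongly on which of the two groups sits here, although each group counts one heavy atom, one hydrogen-bond donor, one hydrogen-bond acceptor and no net charge. No measurement at hand bears on what lies behind a step of this size, so the result stands as an observation on this one pair.

From the compounds shown here alone, how a methylamino group, a methoxy group or a plain hydrogen on this carbon would compare with amino and hydroxy remains open. Also open, going by these compounds, is whether the same swap on the core of compound 1 would give a step of similar size, since a single pair cannot show whether the effect carries over to other substitution on the ring.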